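The source may report more compounds than this note shows. Statements on the series, on what has been measured and on what is new or still open speak of the compounds shown alone.

Three compounds built on one shared core, carrying different aryl groups on the amide-type nitrogen, have been tested in an assay on isolated protein for inhibition of histone deacetylase 4 (Homo sapiens), with a stated time of 1 h; on this read-out higher numbers stand for weaker inhibition and lower numbers for stronger inhibition. Compound 3, `O=C(COc1ccc2cc(/C=C3/SC(=O)NC3=O)ccc2c1)Nc1c(F)cc(F)cc1Br`, gives the highest of the three numbers, at 1100 nM. Compound 1, `O=C(COc1ccc2cc(/C=C3/SC(=O)NC3=O)ccc2c1)Nc1cccc(F)n1`, gives 840 nM, and compound 2, `Cc1cc(Br)ccc1NC(=O)COc1ccc2cc(/C=C3/SC(=O)NC3=O)ccc2c1`, gives 550 nM. None of these numbers stands apart from the others: the change from compound 1 to compound 2 brought a 1.5-fold lower number from compound 1 to compound 2 (0.18 log units; within the scatter), the change from compound 1 to compound 3 brought a 1.3-fold higher number from compound 1 to compound 3 (0.12 log units; within the scatter), and the change from compound 2 to compound 3 brought a 2.0-fold higher number from compound 2 to compound 3 (0.30 log units; within the scatter). All three of these steps swap one aryl group for another on the same nitrogen, and all three stayed within the scatter of the measurement.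

Compound 4, `O=C(COc1ccc2cc(/C=C3/SC(=O)NC3=O)ccc2c1)Nc1cc(Cl)cc(C(F)(F)F)c1`, is the next member of this set. Relative to compound 3 it carries 3-chloro-5-(trifluoromethyl)phenyl in place of 2-bromo-4,6-difluorophenyl on an amide-type nitrogen. Every step of this kind seen so far has been small, so the expectation for compound 4 in this assay is a step of about a 1.2-fold lower number from compound 3 to compound 4 (0.09 log units; within the scatter), which means no change beyond the scatter. Compound 4 is therefore estimated at 900 nM, with a range from 400 nM to 2200 nM.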

Compound 4, half-maximal inhibitory concentration: 4000 nM
For compound 4 the middle estimate is 4.4-fold (0.65 log units) below the measured one; measured number above the stated range.
By their numbers in this assay, from the lowest: compounds 2, 1 and 3 (each within the scatter of the next); then compound 4.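

In this assay, 3-chloro-5-(trifluoromethyl)phenyl on the amide-type nitrogen gives a 3.6-fold higher number from compound 3 to compound 4 (0.56 log units; beyond the scatter), a 4.8-fold higher number from compound 1 to compound 4 (0.68 log units; beyond the scatter) and a 7.3-fold higher number from compound 2 to compound 4 (0.86 log units; beyond the scatter), which makes compound 4 the weakest inhibitor of the four and shows that this position does not accept every aryl group equally, something the steps among compound 1, compound 2 and compound 3 could not show. The counts do not separate the two groups in the step to compound 4: 2-bromo-4,6-difluorophenyl and 3-chloro-5-(trifluoromethyl)phenyl each have one six-membered aromatic ring of carbon only, no hydrogen-bond donors or acceptors and no net charge. No measurement at hand explains the rise in the number.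

Compound 4 carries its chlorine and trifluoromethyl together, so the compounds shown leave open whether one of them alone would give a similar step. Also open, going by these compounds, is how this assay would read for an aryl ring bearing an amine or a carboxylic acid, or for a longer alkyl chain in place of the aryl ring on this nitrogen.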